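A few compounds are considered here, and "the series" means these few. Any claim that something is new, unique, unknown or untested is made for them only; others in the source may bear on it.

Measured so far in a functional assay on the whole organism (strain CF-1) with Mus musculus as the target, in the writhing test, with a stated time of 15 min; on this read-out lower numbers stand for an effect already at smaller amounts and higher numbers for an effect only at larger amounts of compound:

compound 1 `CC(=O)/N=C1\NC2(CCCCO2)CCS1` gives 3.1 mg/kg
compound 2 `O=C(/N=C1\NC2(CCCCO2)CCS1)c1ccc(F)cc1` gives 8.8 mg/kg; 28 mg/kg; 49 mg/kg (3 entries)
compound 3 `O=C(/N=C1\NC2(CCCCO2)CCS1)c1cccc(F)c1` gives 9.2 mg/kg

Compound 3 stands at the highest of the two single numbers; its nearest neighbour is compound 1, and the step of a 3.0-fold higher number from compound 1 to compound 3 (0.47 log units; beyond the scatter) lies beyond the scatter. Compound 2 has no single number, only the spread of its repeated entries (the several entries of compound 2 in this assay, 8.8 mg/kg; 28 mg/kg; 49 mg/kg (3 entries)), which shows how far repeats of this kind can drift.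

Compound 4 `CC(C)(C)C(=O)/N=C1\NC2(CCCCO2)CCS1` differs from compound 3 in one place: tert-butyl in place of 3-fluorophenyl on a carbonyl carbon. For the measured compounds named here, the only measured step that bears on this is a 3.0-fold higher number from compound 1 to compound 3 (0.47 log units; beyond the scatter), where a 3-fluorophenyl replaced an alkyl group on the same carbonyl carbon and the number rose modestly. The present change runs the other way, from 3-fluorophenyl back to an alkyl group, so a step of similar size in the opposite direction, towards the number of compound 1, is expected, with wide uncertainty given (the several entries of compound 2 in this assay, 8.8 mg/kg; 28 mg/kg; 49 mg/kg (3 entries)).

Compound 4 is therefore estimated at 4 mg/kg, with a range of 1.5 mg/kg to 12 mg/kg, which means an expected step of a 2.3-fold lower number from compound 3 to compound 4 (0.36 log units; beyond the scatter).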

Compound 4, dose for half-maximal effect: 200 mg/kg
Beside the measured number, compound 4's estimate is 50-fold (1.70 log units) below it; measured number outside the range, above it.
By their numbers in this assay, from the lowest: compound 1; then compound 3; then compound 4.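

Working notes: in this assay, alkyl in place of aryl on this carbonyl carbon does not by itself return the number towards that of compound 1, since the change to tert-butyl gives a 22-fold higher number from compound 3 to compound 4 (1.34 log units; beyond the scatter) and the change from methyl to tert-butyl gives a 65-fold higher number from compound 1 to compound 4 (1.81 log units; beyond the scatter). The two alkyl groups therefore lie on either side of 3-fluorophenyl, so the alkyl or aryl class of the group does not order these three compounds. This position is far more sensitive than the earlier step suggested, and the new steps also exceed the spread seen in repeats: the several entries of compound 2 in this assay, 8.8 mg/kg; 28 mg/kg; 49 mg/kg (3 entries).

On these data alone, it remains open whether the rise is specific to tert-butyl or builds gradually through ethyl and isopropyl. Also open, as far as these compounds go, is how a longer chain such as n-butyl, or an amine carried on the alkyl group, would behave here.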